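A few compounds are considered here, and "the series" means these few. Any claim that something is new, unique, unknown or untested is made for them only; others in the source may bear on it.

In a functional assay on G-361 cells (Homo sapiens) for cytotoxicity, read by MTT assay, with a stated time of 3 days (a lower number here means a stronger inhibitor, a higher number a weaker inhibitor), compound 1 (`N#Cc1c(NN)nc(SCc2nc3ccccc3[nH]2)nc1-c1ccccc1`) gives 14.7 nM and compound 2 (`N#Cc1c(Nc2ccccn2)nc(SCc2nc3ccccc3[nH]2)nc1-c1ccccc1`) gives 8.9 nM while compound 3 (`N#Cc1c(NNC(N)=S)nc(SCc2nc3ccccc3[nH]2)nc1-c1ccccc1`) gives 3.96 nM as the lowest of the three numbers. Within the data shown here, compound 4 (`N#Cc1c(-c2ccccc2)nc(SCc2nc3ccccc3[nH]2)nc1N1CCNCC1`) carries piperazin-1-yl on an aromatic carbon (a group of 6 heavy atoms (4 carbon, 2 nitrogen; one six-membered non-aromatic ring with 2 hetero atoms) in place of a group of 5 heavy atoms (1 carbon, 3 nitrogen, 1 sulfur; no ring), on an aromatic carbon) and no measured step makes this exact exchange. The nearest evidence is modest: (a 3.7-fold lower number from compound 1 to compound 3 (0.57 log units; beyond the scatter)) and (a 2.2-fold lower number from compound 2 to compound 3 (0.35 log units; beyond the scatter)) lie beyond the scatter, while (a 1.7-fold lower number from compound 1 to compound 2 (0.22 log units; within the scatter)) lies within it. The group entering in (a 3.7-fold lower number from compound 1 to compound 3 (0.57 log units; beyond the scatter)) is absent from compound 4, so a modest rise in this assay is expected. The expected step is (a 2.5-fold higher number from compound 3 to compound 4 (0.40 log units; beyond the scatter)) and no larger shift is anticipated. For compound 4 the estimate is 10 nM with an expected range from 4 nM to 28 nM on present data.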

Compound 4, half-maximal inhibitory concentration: 2.5 nM
Beside the measured number, compound 4's estimate is 4.0-fold (0.60 log units) above it; the whole stated range lies above it.
By their numbers in this assay, from the lowest: compounds 4 and 3 (each within the scatter of the next); then compounds 2 and 1 (each within the scatter of the next).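

In this assay, a non-aromatic ring on this aromatic carbon does as well as the open-chain group: a 1.6-fold lower number from compound 3 to compound 4 (0.20 log units; within the scatter). The same ring also separates from the other two substituents, with a 3.6-fold lower number from compound 2 to compound 4 (0.55 log units; beyond the scatter) and a 5.9-fold lower number from compound 1 to compound 4 (0.77 log units; beyond the scatter), so low numbers at this position do not require the chain group of compound 3. Nothing measured here accounts for these steps.

The compounds shown leave open whether morpholin-4-yl or 4-methylpiperazin-1-yl on this carbon would keep numbers in this range. They also leave open how much the ring's free amine nitrogen contributes.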